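The compounds below may be only part of what the source reports. "The series", "measured", "known", "first", "only" and "open" are said of these compounds alone.

Measured so far:

compound 1, `COc1cnc(-c2ccccn2)nc1N1CCCC1`: > 1000 mL/min/kg
compound 2, `COc1cnc(-c2ccccn2)nc1NCc1ccccc1Cl`: 704 mL/min/kg

In an in vitro ADME assay on microsomes from liver (Mus musculus) for metabolic stability, read by LC-MS, tested at 0.05 uM (a higher number here means faster removal of the compound, a lower number slower removal), compound 1 gives > 1000 mL/min/kg, and this is a limit of the assay rather than a number. Compound 2, which carries a different amine on the same core, gives 704 mL/min/kg in this assay. Compound 1 therefore stands at the limit of > 1000 mL/min/kg in this assay, at which 1 of the 2 values shown sits, so only its position above that edge is known, not how far above it sits.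

Compound 3, `COc1cnc(-c2ccccn2)nc1NC1CCCC1`, keeps the shared core and differs from compound 1 in one place: cyclopentylamino in place of pyrrolidin-1-yl on an aromatic carbon

Among the compounds with values here, no measured pair mirrors this change, so nothing shows what it does in this assay. The step of an at least 1.1-fold lower number from compound 1 to compound 3 (0.04 log units; that floor lies within the scatter) is expected to be small, no larger than the usual scatter, and both measured compounds sit high. Compound 3 is therefore estimated at 900 mL/min/kg, with a range from 350 mL/min/kg to 2500 mL/min/kg.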

Compound 3, clearance: > 1000 mL/min/kg
Compound 3: a limit, no number (the forecaster's own chance of this, stated with the estimate: 40%); middle value at least 1.1-fold (0.04 log units) from the limit.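

In this assay, compound 1 and compound 3 both give a limit rather than a number, so no step between them can be read: the limit of > 1000 mL/min/kg in this assay, at which 2 of the 3 values shown sit.

On these data alone, how far each compound lies past that limit stays open, and so does whether cyclopentylamino in place of pyrrolidin-1-yl changes the clearance at all.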